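Ester capping of the hydroxypropyl chain: cytotoxicity notes

The source may report more compounds than this note shows. Statements on the series, on what has been measured and on what is new or still open speak of the compounds shown alone.

compound 1 `Fc1ccc(-c2cn(-c3ccnc4cc(Cl)ccc34)nn2)cc1`: > 3080000 nM (a limit)
compound 2 `OCCCc1cn(-c2ccnc3cc(Cl)ccc23)nn1`: 151000 nM

In an ADME assay on HepG2 cells (Homo sapiens) for cytotoxicity, read by MTT assay, with a stated time of 24 h (a lower number here means that less compound is tolerated, a higher number that more compound is tolerated), compound 1 reaches only the limit > 3080000 nM. Compound 2 gives 151000 nM. The step of an at least 20-fold lower number from compound 1 to compound 2 (1.30 log units; beyond the scatter). Among the measured compounds shown here, compound 2 thus holds the only number; the other value is a limit (the limit of > 3080000 nM in this assay, at which 1 of the 2 values shown sits). Compound 3 `COc1ccc(C(=O)OCCCc2cn(-c3ccnc4cc(Cl)ccc34)nn2)cc1` carries (4-methoxyphenyl)carbonyl in place of hydrogen on an oxygen on a saturated carbon. For the measured compounds named here, the single measured step concerns a different place and bears on this change only loosely, so no more than a moderate shift is expected. For compound 3 an estimated 2.0-fold higher number from compound 2 to compound 3 (0.30 log units; within the scatter) is taken. Compound 3 is thus expected near 300000 nM, within 80000 nM to 1500000 nM.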

Compound 3, half-maximal cytotoxic concentration: 347000 nM
Estimate against measurement, compound 3: 1.2-fold (0.06 log units) below, and the stated range covers the measured number.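

Capping the oxygen of the hydroxypropyl chain with (4-methoxyphenyl)carbonyl gives, in this assay, a 2.3-fold higher number from compound 2 to compound 3 (0.36 log units; beyond the scatter). This is the first change shown at this oxygen rather than on the aromatic carbon, and it shows that the hydroxyl hydrogen can be replaced without a lower number. With the cap in place, compound 3 still gives a measured number rather than a limit.

On these data alone, whether a smaller acetyl cap, an amine in place of the hydroxyl or a longer chain would shift the number in the same direction remains open. No measured property among the data shown bears on the cause of this step.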